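The compounds below may be only part of what the source reports. "The series", "measured", "known", "first", "only" and "open" are said of these compounds alone.

Measured compounds in an ADME assay on THP-1 cells (Homo sapiens) for cytotoxicity, read by flow cytometry, with a stated time of 72 h; on this read-out higher numbers stand for weaker inhibition and lower numbers for stronger inhibition:

Compound 1 `N/C(=N\O)c1ccc(C2=C(S(=O)(=O)c3ccccc3)CC(c3ccccc3)(c3ccccc3)O2)cc1` gives 30600 nM in this assay.
Compound 2 `N/C(=N\O)c1ccc(C2=C(S(=O)(=O)c3ccc(/C(N)=N/O)cc3)CC(c3ccccc3)(c3ccccc3)O2)cc1` gives 119000 nM in this assay.
Compound 3 `N/C(=N\O)c1ccc(C2=C(S(=O)(=O)c3ccc(Nc4cccc(/C(N)=N/O)c4)cc3)CC(c3ccccc3)(c3ccccc3)O2)cc1` gives > 50000 nM in this assay, which is a limit of the assay and not a number.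

Compound 3 therefore stands only as a limit (the limit of > 50000 nM in this assay, at which 1 of the 3 values shown sits); its place among the three values is not fixed beyond that. Within the data shown here, the step of an at least 1.6-fold higher number from compound 1 to compound 3 (0.21 log units; that floor lies within the scatter) gives a floor that stays within the scatter, while a 3.9-fold higher number from compound 1 to compound 2 (0.59 log units; beyond the scatter) is the one step in the set that clearly moves the read-out. The step that the limit leaves unreadable from compound 2 to compound 3 cannot be read because of the limit.

Compound 4 `N/C(=N\O)c1ccc(C2=C(S(=O)(=O)c3ccc(Nc4ccccc4/C(N)=N/O)cc3)CC(c3ccccc3)(c3ccccc3)O2)cc1` differs from compound 3 by a group of 10 heavy atoms (7 carbon, 2 nitrogen, 1 oxygen; one six-membered aromatic ring of carbon only) in place of a group of 10 heavy atoms (7 carbon, 2 nitrogen, 1 oxygen; one six-membered aromatic ring of carbon only), on a nitrogen on an aromatic ring. Among the measured compounds shown here, none of the measured steps is of this kind, since all three add or swap a group rather than rearranging the same atoms, so no measured step bears on it directly. Compound 4 is expected to sit close to compound 3 in this assay, with a step that the limit leaves unreadable from compound 3 to compound 4 estimated as no step beyond the scatter. For compound 4 the estimate in this assay is 70000 nM, within 25000 nM to 200000 nM, and a limit rather than a number is the more likely outcome.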

Compound 4, half-maximal inhibitory concentration: > 50000 nM
Compound 4: a limit, no number; the forecaster's own chance of this, stated with the estimate: 60%; the middle value does not contradict the limit.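

In this assay compound 4 gives > 50000 nM, a limit of the assay and not a number. Among these compounds, compound 3 and compound 4 have the same atoms, joined differently in the group on a nitrogen on an aromatic ring, and both stand only as limits, so this rearrangement shows no readable change, and neither the step between them nor the step from compound 2 to compound 4 can be read: the limit of > 50000 nM in this assay, at which 2 of the 4 values shown sit. The one readable new step is an at least 1.6-fold higher number from compound 1 to compound 4 (0.21 log units; that floor lies within the scatter), so compound 4 gives only a floor against compound 1, as compound 3 did.

Going by these compounds, the actual values of compound 3 and compound 4 remain open, and with them any difference between the two arrangements. Also open, on these data alone, is what a carboxylic acid or a plain amine would give in place of the group on that nitrogen.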